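A few compounds are considered here, and "the series" means these few. Any claim that something is new, unique, unknown or untested is made for them only; others in the source may bear on it.

Measured compounds in a functional assay on mitochondria from heart for inhibition of peroxisomal acyl-coenzyme A oxidase 1 (Rattus norvegicus); on this read-out higher numbers stand for weaker inhibition and lower numbers for stronger inhibition:

Compound 1 `Cc1nc2cc(OC[C@H](O)CN3CCN(Cc4noc(-c5ccc(C(C)C)cc5)n4)CC3)ccc2s1` gives 950 nM.
Compound 2 `Cc1nc2cc(OC[C@H](O)CN3CCN(Cc4noc(-c5ccc(C(F)(F)F)cc5)n4)CC3)ccc2s1` gives 380 nM.
Compound 3 `Cc1nc2cc(OC[C@H](O)CN3CCN(Cc4noc(-c5ccc(Cl)cc5Cl)n4)CC3)ccc2s1` gives 130 nM.

Compound 3 stands lowest of the three numbers: compound 2 sits nearest, a step of a 2.9-fold lower number from compound 2 to compound 3 (0.47 log units; beyond the scatter) away, and compound 1 furthest, a step of a 7.3-fold lower number from compound 1 to compound 3 (0.86 log units; beyond the scatter) away. Both steps lie beyond the scatter, so compound 3 is the strongest inhibitor among the measured compounds.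

Compound 4 `Cc1cccc(-c2nc(CN3CCN(C[C@@H](O)COc4ccc5sc(C)nc5c4)CC3)no2)c1` differs from compound 3 in one place: 3-methylphenyl in place of 2,4-dichlorophenyl on an aromatic carbon. The shared core is kept.

Among the measured compounds shown here, two measured steps bear on this change, since both replace one phenyl group on the same aromatic carbon by another: from 4-isopropylphenyl to 2,4-dichlorophenyl the number fell by a 7.3-fold lower number from compound 1 to compound 3 (0.86 log units; beyond the scatter), and from 4-(trifluoromethyl)phenyl to 2,4-dichlorophenyl it fell by a 2.9-fold lower number from compound 2 to compound 3 (0.47 log units; beyond the scatter). For the measured compounds named here, no measured step shows a 3-methylphenyl, so its effect is uncertain. Because a 7.3-fold lower number from compound 1 to compound 3 (0.86 log units; beyond the scatter) and a 2.9-fold lower number from compound 2 to compound 3 (0.47 log units; beyond the scatter) both pair the 2,4-dichlorophenyl with the lower number and any other phenyl group with a higher one, a modest rise beyond the scatter is expected from compound 3 to compound 4, estimated as a 3.8-fold higher number from compound 3 to compound 4 (0.59 log units; beyond the scatter).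

Compound 4 is therefore estimated to give 500 nM, with a range from 200 nM to 1500 nM.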

Compound 4, half-maximal inhibitory concentration: 6500 nM
For compound 4 the middle estimate is 13-fold (1.11 log units) below the measured one, and the stated range ends below it.
By their numbers in this assay, from the lowest: compound 3; then compound 2; then compound 1; then compound 4.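

In this assay, exchanging one phenyl group for another on this carbon of the five-membered ring can produce a large step, as seen in a 50-fold higher number from compound 3 to compound 4 (1.70 log units; beyond the scatter) and in a 17-fold higher number from compound 2 to compound 4 (1.23 log units; beyond the scatter), while a 6.8-fold higher number from compound 1 to compound 4 (0.84 log units; beyond the scatter) is modest but still beyond the scatter. Among these four compounds, the two phenyl groups carrying only carbon substituents give the two highest numbers, and the phenyl groups carrying chlorine or trifluoromethyl give the two lowest, with no compound going against this. Nothing measured here gives a reason for this difference.

As far as these compounds go, these phenyl groups differ in both the kind and the placement of their substituents, so the contribution of each remains open. Plain phenyl, 3-chlorophenyl and 4-methylphenyl in this place would help to separate the two.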